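A few compounds are considered here, and "the series" means these few. Any claim that something is new, unique, unknown or untested is made for them only; others in the source may bear on it.

Compound 1 `C=C1CC[C@@H]2[C@](C)(COC(C)=O)[C@H](OC(C)=O)CC[C@@]2(C)[C@H]1CC(Nc1ccc(S(=O)(=O)Nc2ccc(Cl)nn2)cc1)C1=CCOC1=O` is one of three related compounds tested in a functional assay on CCRF-CEM cells (Homo sapiens) for inhibition, read by sulforhodamine B assay, with a stated time of 48 h (on this read-out higher numbers stand for weaker inhibition of growth and lower numbers for stronger inhibition of growth), where compound 1 gives 2600 nM. Compound 2 `C=C1CC[C@@H]2[C@](C)(COC(C)=O)[C@H](OC(C)=O)CC[C@@]2(C)[C@H]1CC(Nc1ccc(S(=O)(=O)Nc2nccc(C)n2)cc1)C1=CCOC1=O` gives 3090 nM and compound 3 `C=C1CC[C@@H]2[C@](C)(COC(C)=O)[C@H](OC(C)=O)CC[C@@]2(C)[C@H]1CC(Nc1ccc(S(=O)(=O)Nc2ncccn2)cc1)C1=CCOC1=O` gives 3410 nM. Compound 1 has the lowest of these three numbers, but the gaps to compounds 2 and 3 are within the scatter. Compound 4 `C=C1CC[C@@H]2[C@](C)(COC(C)=O)[C@H](OC(C)=O)CC[C@@]2(C)[C@H]1CC(Nc1ccc(S(=O)(=O)Nc2nccs2)cc1)C1=CCOC1=O` differs from compound 1 in one place: 1,3-thiazol-2-yl in place of 6-chloropyridazin-3-yl on a sulfonamide nitrogen. The earlier swaps at this same nitrogen were a 1.2-fold higher number from compound 1 to compound 2 (0.07 log units; within the scatter) and a 1.3-fold higher number from compound 1 to compound 3 (0.12 log units; within the scatter), both within the scatter, so for compound 4 no step beyond the scatter is expected in this assay, and the estimated step is a 1.2-fold higher number from compound 1 to compound 4 (0.06 log units; within the scatter). Compound 4 is therefore expected to give about 3000 nM, with a range from 1500 nM to 6000 nM.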

Compound 4, concentration for total growth inhibition: 6760 nM
Estimate against measurement, compound 4: 2.3-fold (0.35 log units) below; measured number above the stated range.
By their numbers in this assay, from the lowest: compounds 1, 2, 3 and 4 (each within the scatter of the next, the first and the last beyond it).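

At this sulfonamide nitrogen in this assay, the group is not freely interchangeable: 1,3-thiazol-2-yl gives a 2.6-fold higher number from compound 1 to compound 4 (0.41 log units; beyond the scatter) and a 2.2-fold higher number from compound 2 to compound 4 (0.34 log units; beyond the scatter), both modest steps, while a 2.0-fold higher number from compound 3 to compound 4 (0.30 log units; within the scatter) stays inside the scatter. Going by these compounds alone, the earlier swaps, all among six-membered aromatic rings, gave no step beyond the scatter, so this five-membered ring is the first change here to exceed it, though not against every partner. No evidence is available that explains these steps.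

Still open, as far as these compounds go, is whether the ring size or the sulfur matters more. A 1,3-oxazol-2-yl group, with oxygen in place of sulfur, would help separate the two.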